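This account rests on a few compounds, and the source may have more. Where it says the series, first, only, none or still open, it means among the compounds named here.

In an ADME assay on MDBK cells (Bos taurus) for cytotoxicity, read by MTT assay, with a stated time of 72 h (on this read-out higher numbers stand for lower toxicity in this test and lower numbers for higher toxicity in this test), compound 1 (`Cc1ccc(-c2nn(-c3ccccc3)cc2CNc2ccc(Br)cc2)cc1`) gives > 100000 nM as a limit of the assay. Compound 2 (`Clc1ccc(NCc2cn(-c3ccccc3)nc2-c2ccc(Cl)cc2)cc1`) gives > 100000 nM and this is also a limit. Compound 3 (`Cc1ccc(-c2nn(-c3ccccc3)cc2CNc2ccc(C(F)(F)F)cc2)cc1`) gives > 100000 nM and that too is only a limit. The three therefore stand together (the limit of > 100000 nM in this assay, at which 3 of the 3 values shown sit) with no number by which to rank them.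

Compound 4 (`Cc1ccc(-c2nn(-c3ccccc3)cc2CNc2ccc(Cl)cc2)cc1`) differs from compound 3 by one change (chloro in place of trifluoromethyl on an aromatic carbon) with chloro in place of trifluoromethyl on an aromatic carbon, para to a large group. Among the measured compounds shown here, the one measured step at that place is a step that the two limits leave unreadable from compound 1 to compound 3 with trifluoromethyl in place of bromo, and it offers no size to carry over. Compound 2 also carries the 4-chlorophenyl group, and its value is likewise a limit. For the measured compounds named here, with a step that the two limits leave unreadable from compound 1 to compound 3 as the only measured guide, no step beyond the scatter is expected in this assay and the estimated step is a number no higher from compound 3 to compound 4 (the limit leaves the size open) without a favoured direction. Compound 4 is estimated at 100000 nM with an expected range of 60000 nM to 200000 nM and will probably read as a limit again.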

Compound 4, half-maximal cytotoxic concentration: > 100000 nM
Compound 4 gave a limit, no number (the forecaster's own chance of this, stated with the estimate: 90%); the middle value lies on the limit itself.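

No step can be read between compound 4 and compound 1, compound 2 or compound 3 in this assay, and the four stand together: the limit of > 100000 nM in this assay, at which 4 of the 4 values shown sit. The compounds shown leave open whether chloro, bromo, trifluoromethyl or methyl at these places makes any difference in this test.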